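This account rests on a few compounds, and the source may have more. Where it says the series, first, only, none or still open, it means among the compounds named here.

Compound 1 `CN1CCC(C(=O)N2Cc3c(NC(=O)c4cc(F)cc(F)c4)n[nH]c3C2(C)C)CC1`: > 225000 nM
Compound 2 `CN1CCC(C(=O)N2Cc3c(NC(=O)Nc4cccc(F)c4)n[nH]c3C2(C)C)CC1`: > 225000 nM

In a physicochemical assay for solubility, at pH 7 (on this read-out higher numbers stand for higher solubility and lower numbers for lower solubility), compound 2 gives > 225000 nM, which is a limit of the assay and not a number. Compound 1 gives > 225000 nM, also a limit. Among the compounds with values here, both share (the limit of > 225000 nM in this assay, at which 2 of the 2 values shown sit), so the only measured step, a step that the two limits leave unreadable from compound 1 to compound 2, has no size to carry forward.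

Compound 3 `CN1CCC(C(=O)N2Cc3c(NC(=O)c4ccc(C(F)(F)F)cc4)n[nH]c3C2(C)C)CC1` follows from compound 2 by one change: 4-(trifluoromethyl)phenyl in place of (3-fluorophenyl)amino on a carbonyl carbon. Compound 1 also holds an aromatic ring of carbon only on that carbonyl carbon, and its > 225000 nM is a limit.

No step beyond the scatter is therefore expected in this assay, and the estimated step is an at least 1.1-fold lower number from compound 2 to compound 3 (0.05 log units; that floor lies within the scatter). For compound 3 the expected value is 200000 nM, with an estimated range of 90000 nM to 300000 nM.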

Compound 3, solubility: 191000 nM
Beside the measured number, compound 3's estimate is 1.0-fold (0.02 log units) above it, within the range that was stated.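

In this assay, within the data shown here, compound 3 gives 191000 nM, the first value on this carbonyl carbon that is a number and not a limit. Placing 4-(trifluoromethyl)phenyl there instead of (3-fluorophenyl)amino gives an at least 1.1-fold lower number from compound 2 to compound 3 (0.07 log units; that floor lies within the scatter), and placing it there instead of 3,5-difluorophenyl gives an at least 1.1-fold lower number from compound 1 to compound 3 (0.07 log units; that floor lies within the scatter). Both steps are only floors, because the values they start from are limits: the limit of > 225000 nM in this assay, at which 2 of the 3 values shown sit.

As far as these compounds go, the true size of either step stays open. So does the value in this assay for a phenyl ring carrying a carboxylic acid or an amine on this carbonyl carbon.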